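This account rests on a few compounds, and the source may have more. Where it says the series, first, only, none or still open, it means among the compounds named here.

Working notes on the series, all read in an assay on isolated protein for inhibition of Nitric oxide synthase, inducible (Homo sapiens), read by scintillation counting, with a stated time of 30 min, tested at 50 uM; on this read-out higher numbers stand for more inhibition at the one concentration tested (going by the name of the read-out) and lower numbers for less inhibition:

compound 1, `CCC(=O)N1N=C(c2cc(OC)ccc2N)SC1(C)C`, gives 73%
compound 2, `CCCC(=O)N1N=C(c2cc(OC)ccc2N)SC1(C)C`, gives 91.1%
compound 3, `CCCC(=O)N1N=C(c2cc(Cl)ccc2N)SC1(C)C`, gives 66.2%

From compound 1 to compound 2 the change is methyl in place of hydrogen on a saturated chain carbon, two bonds along the chain from a carbonyl carbon, and it gave a number 18.1 percentage points higher from compound 1 to compound 2 (beyond the scatter). Compound 2 to compound 3 gave a number 24.9 percentage points lower from compound 2 to compound 3 (beyond the scatter). The difference between the core of compound 1 and the core of compound 3 is not broken down here; compound 3 stands lowest of the three, though its gap to compound 1 lies within the scatter.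

Compound 4, `CCCCC(=O)N1N=C(c2cc(Cl)ccc2N)SC1(C)C`, is not yet measured. It differs from compound 3 by methyl in place of hydrogen on a saturated chain carbon, three bonds along the chain from a carbonyl carbon. This is the same kind of change as that from compound 1 to compound 2, not the same: there the added methyl sits two bonds along the chain from the carbonyl carbon, here three bonds along. Resting on the step from compound 1 to compound 2 in this assay , and allowing that the change now sits one bond further out on a different core, the expected step is a number 11.8 percentage points higher from compound 3 to compound 4 (beyond the scatter). Compound 4 is estimated at 78%, between 60% and 93%.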

Compound 4, a percentage reported as inhibition, at one concentration (the size of the read-out at that concentration, not a potency): 12.6%
Compound 4: middle estimate off by 65.4 percentage points, on the high side, and the stated range ends above it.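

In this assay the added methyl gave a number 53.6 percentage points lower from compound 3 to compound 4 (beyond the scatter), so the direction of the earlier step did not carry over from one core to the other: the same change on two cores in this assay, a number 18.1 percentage points higher (beyond the scatter) from compound 1 to compound 2 and a number 53.6 percentage points lower (beyond the scatter) from compound 3 to compound 4, 71.7 percentage points apart, beyond the scatter of two such steps

The two steps differ in place as well as in core, with the methyl two bonds along the chain from a carbonyl carbon in one and three bonds along in the other, and these compounds cannot separate the two. Two steps also set no rule for any other core or chain.

Still open, as far as these compounds go, is how the butyl chain reads with methoxy in place of chloro, a comparison that would hold the place of the change fixed and vary only the core. Also open, from the compounds shown here alone, is how a longer chain than butyl, or an amine in place of the chloro, would read on this series.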